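The compounds below may be only part of what the source reports. "The series", "measured", "known", "first", "only" and "open" are said of these compounds alone.

The two measured compounds, with their values in a functional assay on the whole organism with Mus musculus as the target, with a stated time of 1 h; on this read-out lower numbers stand for an effect already at smaller amounts and higher numbers for an effect only at larger amounts of compound:
compound 1 `Cc1ccccc1-c1nnc(NN)s1` gives 30 mg/kg
compound 2 `Cc1ccccc1-c1nnc(NNC(C)C)s1` gives 54 mg/kg

Within the data shown here, compound 2 shows the higher of the two numbers, but the only measured step, a 1.8-fold higher number from compound 1 to compound 2 (0.26 log units; within the scatter), lies within the usual scatter of this kind of test, so the two compounds cannot be told apart on this read-out. Compound 3 `Cc1ccccc1-c1nnc(NNC2CCCC2)s1` has not yet been measured. It differs from compound 2 in a single place: cyclopentyl in place of isopropyl on an amine nitrogen. Among the measured compounds shown here, the one step measured so far put isopropyl in place of hydrogen on that same amine nitrogen; the present change swaps one alkyl group for another at the same spot, and no measured step covers such a swap directly. For the measured compounds named here, the only guide is that the change already made at this nitrogen, a 1.8-fold higher number from compound 1 to compound 2 (0.26 log units; within the scatter), stayed within the scatter, which gives no reason to expect a larger shift now. For compound 3 the estimate in this assay is therefore 55 mg/kg, with a range from 25 mg/kg to 120 mg/kg. The expected step is a 1.0-fold higher number from compound 2 to compound 3 (0.01 log units; within the scatter), that is, no change beyond the scatter.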

Compound 3, dose for half-maximal effect: > 100 mg/kg
Compound 3: a limit, no number; the forecaster's own chance of this, stated with the estimate: 5%; middle value at least 1.8-fold (0.25 log units) away from the limit.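

In this assay compound 3 gives no exact number, only a limit: the limit of > 100 mg/kg in this assay, at which 1 of the 3 values shown sits. Even so, the limit can be compared with the two earlier compounds, and it gives an at least 1.8-fold higher number from compound 2 to compound 3 (0.26 log units; that floor lies within the scatter), a floor that on its own does not separate cyclopentyl from isopropyl, and an at least 3.3-fold higher number from compound 1 to compound 3 (0.52 log units; beyond the scatter), the first step at this amine nitrogen that clears the scatter. Compounds 1 and 2 could not be told apart, so the position looked indifferent to what was placed on it, whereas cyclopentyl in place of hydrogen shows that a substituent here can push the effect to clearly larger doses.

The compounds shown do not reveal how far beyond its limit compound 3 lies, or whether the change goes with the ring itself or simply with the larger number of carbons. A straight pentyl chain or a small cyclopropyl group on this same nitrogen would help to separate those two readings.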